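This account rests on a few compounds, and the source may have more. Where it says the series, first, only, none or still open, it means among the compounds named here.

Measured so far in a functional assay on A549 cells (Homo sapiens) for antiproliferative activity, with a stated time of 5 days; a lower number here means a stronger inhibitor, a higher number a weaker inhibitor:
- compound 1 `O=C1C=CC2(C=C1)OCC(=O)N2c1nc(-c2ccc3c(c2)OCCO3)nn1-c1ccccc1`: 170 nM
- compound 2 `Cc1ccc(-n2nc(-c3ccc4ccccc4c3)nc2N2C(=O)C(C)OC23C=CC(=O)C=C3)cc1`: 1210 nM

Compound 1 has the lower of these two numbers, which makes it the stronger inhibitor of the pair, and the gap to compound 2 lies beyond the usual scatter. Compound 3 `O=C1C=CC2(C=C1)OCC(=O)N2c1nc(-c2cccc3ccccc23)nn1-c1ccccc1` has not yet been measured. It keeps the core of compound 1 and changes a single group: naphthalen-1-yl in place of 2,3-dihydro-1,4-benzodioxin-6-yl on an aromatic carbon.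

Going by the values given here, no two measured compounds differ in only one place, so the effect of this swap in this assay has not been seen directly. Among the compounds with values here, the only hint is that compound 2, which also carries a naphthalene group, gives 1210 nM, although it differs from compound 1 elsewhere too. A moderate loss of strength therefore seems likely, though a change within the scatter cannot be ruled out. The expected step is a 2.5-fold higher number from compound 1 to compound 3 (0.39 log units; beyond the scatter). For compound 3 the estimated value is 420 nM, with an expected range from 120 nM to 1500 nM.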

Compound 3, half-maximal inhibitory concentration: 80 nM
Estimate against measurement, compound 3: 5.3-fold (0.72 log units) above; measured number outside the range, below it.
By their numbers in this assay, from the lowest: compound 3; then compound 1; then compound 2.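

Going by these compounds alone, this is the first direct reading of a change at this position, the aromatic carbon of the five-membered aromatic ring with 3 nitrogen: in this assay, putting naphthalen-1-yl in place of 2,3-dihydro-1,4-benzodioxin-6-yl gives a 2.1-fold lower number from compound 1 to compound 3 (0.33 log units; beyond the scatter), a modest but real improvement. Both groups have 10 heavy atoms, but the entering group is made of carbon only and has no hydrogen-bond acceptors, so the two ring oxygens of the leaving group are not needed for a number this low on the shared core. No measurement available here explains why the all-carbon group gives the lower number, so this single step records an effect without giving its cause.

Going by these compounds, it remains open whether the gain depends on having two fused aromatic rings or on how they are attached, which a quinoline ring or a single pyridine ring at the same carbon would help to test. An amine or a carboxylic acid on the naphthalene would further show how much change this position accepts in this assay.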